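The compounds below may be only part of what the source reports. "The series", "measured", "known", "first", "only" and "open" are said of these compounds alone.

Measured in a functional assay on MCF7 cells (Homo sapiens) for antiproliferative activity, read by MTT assay, with a stated time of 48 h; a higher number here means a weaker inhibitor, a lower number a stronger inhibitor:
- Compound 1 `Cc1ccc(-c2nnc(NC(=O)/C=C/c3ccc(C(F)(F)F)cc3)s2)cc1`: 1.1 ug/mL
- Compound 2 `COc1ccc(-c2nnc(NC(=O)/C=C/c3ccc(C)cc3)s2)cc1`: 0.31 ug/mL
- Compound 3 `COc1ccc(-c2nnc(NC(=O)/C=C/c3ccccc3)s2)cc1`: 0.78 ug/mL

Compound 3 lies within the scatter of compound 1, while compound 2 has a clearly lower number. Compound 4 `COc1ccc(-c2nnc(NC(=O)/C=C/c3ccc(C(F)(F)F)cc3)s2)cc1` is made from compound 3 by one change: trifluoromethyl in place of hydrogen on an aromatic carbon. Going by the values given here, the one measured step that bears on this is a 2.5-fold higher number from compound 2 to compound 3 (0.40 log units; beyond the scatter), a modest change at the same ring carbon. Read in reverse, it suggests that a group there may lower the number, but methyl is not trifluoromethyl. Compound 1 carries trifluoromethyl too, but it differs from compound 4 elsewhere. A slightly lower number is therefore expected, possibly no change beyond the scatter. The expected step is a 1.4-fold lower number from compound 3 to compound 4 (0.15 log units; within the scatter). For compound 4 the estimate is 0.55 ug/mL, with an expected range from 0.2 ug/mL to 1.5 ug/mL.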

Compound 4, half-maximal inhibitory concentration: 0.79 ug/mL
Compound 4: middle estimate off by 1.4-fold (0.16 log units), on the low side; low and high end bracket the measured number.
By their numbers in this assay, from the lowest: compound 2; then compounds 3, 4 and 1 (each within the scatter of the next).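

In this assay, trifluoromethyl on this ring carbon gives a 1.0-fold higher number from compound 3 to compound 4 (0.01 log units; within the scatter), so it does not separate the two compounds, while replacing methyl with it gives a 2.5-fold higher number from compound 2 to compound 4 (0.41 log units; beyond the scatter). So, at this carbon, methyl stands apart from both hydrogen and trifluoromethyl; methoxy in place of methyl elsewhere gives a 1.4-fold lower number from compound 1 to compound 4 (0.14 log units; within the scatter). No measurement here accounts for these results. On these data alone, whether an amine or a carboxylic acid at this carbon would fall with methyl or with trifluoromethyl stays open.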